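This account rests on a few compounds, and the source may have more. Where it says the series, first, only, none or still open, it means among the compounds named here.

Compound 1 `O=C(CCCCC1CCSS1)NCc1cn(CCCOc2ccc3ccc(=O)oc3c2)nn1`: 37.8%
Compound 2 `CC(=O)c1cc2ccc(OCCCn3cc(CNC(=O)CCCCC4CCSS4)nn3)cc2oc1=O`: 34.6%
Compound 3 `COc1ccc(-c2cc3ccc(OCCCn4cc(CNC(=O)CCCCC5CCSS5)nn4)cc3oc2=O)cc1`: 42%

All three share one core and were examined in a functional assay on PC-12 cells (Rattus norvegicus) for cytotoxicity, read by MTT assay, with stated times of 3 h and 2 h, tested at 0.1 uM; a lower number here means a weaker effect, a higher number a stronger effect of the compound at the concentration tested. Compound 1 stands second highest of the three numbers; the nearest is a number 3.2 percentage points lower from compound 1 to compound 2 (within the scatter) and the furthest is a number 4.2 percentage points higher from compound 1 to compound 3 (within the scatter), both within the scatter. The remaining pair shows a number 7.4 percentage points higher from compound 2 to compound 3 (within the scatter), also within the scatter. Compound 4 `O=C(CCCCC1CCSS1)NCc1cn(CCCOc2ccc3cc(-c4ccc(Cl)cc4)c(=O)oc3c2)nn1` differs from compound 1 in one place: 4-chlorophenyl in place of hydrogen on an aromatic carbon. The measured step that bears on it is a number 4.2 percentage points higher from compound 1 to compound 3 (within the scatter), where a 4-methoxyphenyl entered on an aromatic carbon in the same way and stayed within the scatter. A 4-chlorophenyl entering there is therefore expected to give a number 2.2 percentage points higher from compound 1 to compound 4 (within the scatter), nothing beyond the scatter. Compound 4 is estimated at 40%, ranging from 30% to 50%.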

Compound 4, a percentage reported as activity, at one concentration (the size of the read-out at that concentration, not a potency): 40.9%
For compound 4 the middle estimate is 0.9 percentage points below the measured one; measured number inside the range.
By their numbers in this assay, from the lowest: compounds 2, 1, 4 and 3 (each within the scatter of the next).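

In this assay, 4-chlorophenyl on this aromatic carbon gives a number 3.1 percentage points higher from compound 1 to compound 4 (within the scatter) and so, like 4-methoxyphenyl, produces no shift beyond the scatter. Chloro in place of methoxy on that phenyl ring gives a number 1.1 percentage points lower from compound 3 to compound 4 (within the scatter) and 4-chlorophenyl in place of acetyl gives a number 6.3 percentage points higher from compound 2 to compound 4 (within the scatter) so neither change of group at this position separates the compounds. No evidence is available to explain these numbers.

Still open, going by these compounds, is whether an amine or a carboxylic acid on the phenyl ring would move the number beyond the scatter. The same question stands for a longer chain on this carbon.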